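Growth inhibition notes: replacing formyl on the chain

The compounds below may be only part of what the source reports. "The series", "measured", "known", "first", "only" and "open" are said of these compounds alone.

In a functional assay on NCI-H322 cells (Homo sapiens) for antiproliferative activity (on this read-out lower numbers stand for stronger inhibition of growth and higher numbers for weaker inhibition of growth), compound 1 (`COCCCCCCCCCCCCCCC/C=C1\CC(CO)(COC(=O)C(C)(C)C)OC1=O`) gives > 10 ug/mL, a limit. Compound 2 (`CC(C)(C)C(=O)OCC1(CO)C/C(=C\CCCCCCCCCCCCCCC=O)C(=O)O1`) gives > 10 ug/mL, also a limit, so it has no numerical position in the series: the limit of > 10 ug/mL in this assay, at which 2 of the 2 values shown sit. Compound 3 (`CC(C)(C)C(=O)OCCCCCCCCCCCCCCC/C=C1\CC(CO)(COC(=O)C(C)(C)C)OC1=O`) carries (((tert-butyl)carbonyl)oxy)methyl in place of formyl on a saturated chain carbon, ten or more bonds along the chain from a double-bonded chain carbon. Going by the values given here, the only measured step, a step that the two limits leave unreadable from compound 1 to compound 2, supplies no size, so no clear shift in this assay is expected. The expected change is a step that the limit leaves unreadable from compound 2 to compound 3, with no firm direction. For compound 3 the estimate is 14 ug/mL, expected within 6 ug/mL to 35 ug/mL.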

Compound 3, concentration for 50% growth inhibition: > 10 ug/mL
Compound 3 was reported as a limit; the forecaster's own chance of this, stated with the estimate: 75%; the middle value lies beyond the limit too.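

No new step can be read among compound 1, compound 2 and compound 3, as each value is a limit: the limit of > 10 ug/mL in this assay, at which 3 of the 3 values shown sit.

The compounds shown leave open whether methoxymethyl, formyl and (((tert-butyl)carbonyl)oxy)methyl differ at all in growth inhibition.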